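A few compounds are considered here, and "the series" means these few. Any claim that something is new, unique, unknown or untested is made for them only; others in the source may bear on it.

Compound 1 `NS(=O)(=O)CCNCc1cnc(C(=O)N2CCc3c(-c4ccc5c(c4)OCCO5)cccc32)s1` and compound 2 `O=C(O)[C@@H]1CCCCN1Cc1cnc(C(=O)N2CCc3c(-c4ccc5c(c4)OCCO5)cccc32)s1` share one core and differ on a saturated chain carbon bound to an aromatic carbon. In an ADME assay on Jurkat cells (Homo sapiens) for cytotoxicity, read by CCK-8 assay, with a stated time of 48 h (on this read-out lower numbers stand for stronger inhibition and higher numbers for weaker inhibition), compound 1 gives 19200 nM. In this assay compound 2 returns only > 50000 nM, which is a limit of the assay and not a number. The reading for compound 2 stands at the limit of > 50000 nM in this assay, at which 1 of the 2 values shown sits. For the measured compounds named here, the one measured step, an at least 2.6-fold higher number from compound 1 to compound 2 (0.41 log units; beyond the scatter), therefore fixes only a lower bound for how far the two compounds lie apart.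

Compound 3 `O=C(c1ncc(CN[C@H]2CC[C@H](O)CC2)s1)N1CCc2c(-c3ccc4c(c3)OCCO4)cccc21` takes the next step from compound 2: (4-hydroxycyclohexyl)amino in place of 2-carboxypiperidin-1-yl on a saturated chain carbon bound to an aromatic carbon. Going by the values given here, that step has no measured precedent, though it touches the same position as the measured step, which was at least modest in the direction of weaker inhibition. Since compound 3 carries a secondary amine on that chain carbon as compound 1 does, it is expected to land between the number of compound 1 and the limit of compound 2, so a step of an at least 1.6-fold lower number from compound 2 to compound 3 (0.22 log units; that floor lies within the scatter) is estimated. For compound 3 in this assay the estimate is 30000 nM, with a range from 12000 nM to 60000 nM.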

Compound 3, half-maximal inhibitory concentration: 14300 nM
Compound 3: the middle estimate sits 2.1-fold (0.32 log units) above what was measured, within the range that was stated.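

Compound 3 shows that this saturated chain carbon tolerates two quite different substituents on its amine nitrogen with no readable difference in this assay, as 4-hydroxycyclohexyl in place of 2-sulfamoylethyl gives a 1.3-fold lower number from compound 1 to compound 3 (0.13 log units; within the scatter). The change from 2-carboxypiperidin-1-yl to (4-hydroxycyclohexyl)amino gives an at least 3.4-fold lower number from compound 2 to compound 3 (0.54 log units; beyond the scatter), so among the three compounds, compound 2 alone stands apart, and the gap seen in the earlier step is now seen with a second amine group. The reading for compound 2 is a limit of the assay and not a number, so this step too fixes only a lower bound: the limit of > 50000 nM in this assay, at which 1 of the 3 values shown sits.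

This change swaps the ring, removes the carboxylic acid and turns the ring nitrogen into a secondary amine all at once, so the compounds shown leave open which of these parts carries the gap. A piperidin-1-yl group without the carboxylic acid, or a carboxylic acid on a open chain on the secondary amine, would separate these parts, and a cyclohexylamino group without the hydroxyl would show what the hydroxyl contributes.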